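The source may hold more compounds than are shown below. What is called first, only, known or untested is meant among the compounds shown, and "the series" means these compounds.

Measured in a functional assay (trachea) with Cavia porcellus as the target; a higher number here means a weaker inhibitor, a lower number a stronger inhibitor:
- compound 1 `Cn1nc(-c2cccnc2)c2ccccc2c1=O`: 11500 nM
- compound 2 `CCCCn1nc(-c2cccnc2)c2ccccc2c1=O`: 2290 nM
- compound 3 `C=CCn1nc(-c2cccnc2)c2ccccc2c1=O`: 2140 nM

Compound 3 stands at the low end of this short series, but it does not stand there alone. The gap to its nearest neighbour is a 1.1-fold lower number from compound 2 to compound 3 (0.03 log units; within the scatter), which lies within the scatter, so the two cannot be told apart. The gap to the remaining compound is clear, at a 5.4-fold lower number from compound 1 to compound 3 (0.73 log units; beyond the scatter).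

The compound still unmeasured is compound 4 `O=c1c2ccccc2c(-c2cccnc2)nn1C1CCCC1`. Its difference from compound 3 is cyclopentyl in place of allyl on an aromatic nitrogen.

Two measured steps changed the same position and both lowered the number modestly: a 5.0-fold lower number from compound 1 to compound 2 (0.70 log units; beyond the scatter) and a 5.4-fold lower number from compound 1 to compound 3 (0.73 log units; beyond the scatter). Beyond that point, the swap of one extension for another, a 1.1-fold lower number from compound 2 to compound 3 (0.03 log units; within the scatter), showed no change outside the scatter. Among the compounds with values here, none of the measured compounds carries a ring at this position, so the expectation is an extrapolation and its range is kept wide. In this assay no step beyond the scatter is expected, in either direction.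

For compound 4 the estimated value is 2000 nM, with an expected range of 700 nM to 6000 nM. This estimate means an expected 1.1-fold lower number from compound 3 to compound 4 (0.03 log units; within the scatter).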

Compound 4, half-maximal inhibitory concentration: 2750 nM
Compound 4: middle estimate off by 1.4-fold (0.14 log units), on the low side; the measured number falls inside the stated range.
By their numbers in this assay, from the lowest: compounds 3, 2 and 4 (each within the scatter of the next); then compound 1.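

In this assay, within the data shown here, cyclopentyl is the first group at this position to bring a ring, one five-membered non-aromatic ring of carbon only, and it reads no differently from the open chains: allyl gives way to it with no step outside the scatter (a 1.3-fold higher number from compound 3 to compound 4 (0.11 log units; within the scatter)), and the same holds for butyl (a 1.2-fold higher number from compound 2 to compound 4 (0.08 log units; within the scatter)). Against methyl the ring still gives a step beyond the scatter (a 4.2-fold lower number from compound 1 to compound 4 (0.62 log units; beyond the scatter)), so among these four compounds only the methyl compound stands apart, while allyl, butyl and cyclopentyl cannot be separated, whether the group is open or closed into a ring and whether or not it has a double bond. Nothing available here offers an explanation for why these three groups read alike.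

Still open, as far as these compounds go, is whether a longer chain such as octyl, a benzyl group, or a chain ending in an amine or a carboxylic acid would stay at this level or move away from it. All four compounds also carry the same pyridin-3-yl group, so they leave open whether the pattern at the ring nitrogen would hold with another group in its place.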